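This account rests on a few compounds, and the source may have more. Where it says the series, first, only, none or still open, it means among the compounds named here.

Compound 1 `Cc1cc(-c2c(F)cc3c(=O)c(Cc4ccc(Cl)cc4)cn(C4CC4)c3c2F)cc(C)n1` carries a 4-chlorophenyl on the saturated chain carbon and, in a functional assay on P388 cells (Mus musculus) for cytotoxicity (on this read-out higher numbers stand for weaker inhibition and lower numbers for stronger inhibition), compound 1 gives 20000 nM, the highest number of the three measured in the series. Compound 3 `Cc1cc(-c2c(F)cc3c(=O)c(Cc4ccc(O)cc4)cn(C4CC4)c3c2F)cc(C)n1`, with hydroxy in place of chloro, gives 1500 nM in this assay; compound 2 `Cc1cc(-c2c(F)cc3c(=O)c(Cc4ccc(O)cc4O)cn(C4CC4)c3c2F)cc(C)n1`, with 2,4-dihydroxyphenyl, gives 210 nM. The measured steps are a 13-fold lower number from compound 1 to compound 3 (1.12 log units; beyond the scatter), a 95-fold lower number from compound 1 to compound 2 (1.98 log units; beyond the scatter) and a 7.1-fold higher number from compound 2 to compound 3 (0.85 log units; beyond the scatter).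

Compound 4 `Cc1cc(-c2c(F)cc3c(=O)c(Cc4cc(O)ccc4O)cn(C4CC4)c3c2F)cc(C)n1` differs from compound 1 by 2,5-dihydroxyphenyl in place of 4-chlorophenyl on a saturated chain carbon bound to an aromatic carbon. The change shares its starting point with the move to compound 2, and both hydroxy steps from compound 1 lowered the number well beyond the scatter; the move from 2,4-dihydroxyphenyl to 2,5-dihydroxyphenyl is not covered by any measured pair, so the size is less certain than the direction. A large step down is therefore expected, a 40-fold lower number from compound 1 to compound 4 (1.60 log units; beyond the scatter), though probably not reaching the full gain seen in a 95-fold lower number from compound 1 to compound 2 (1.98 log units; beyond the scatter). For compound 4 the estimate in this assay is 500 nM, within a range of 100 nM to 3000 nM.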

Compound 4, half-maximal inhibitory concentration: 360 nM
For compound 4 the middle estimate is 1.4-fold (0.14 log units) above the measured one, within the range that was stated.
By their numbers in this assay, from the lowest: compounds 2 and 4 (each within the scatter of the next); then compound 3; then compound 1.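

In this assay the step of a 56-fold lower number from compound 1 to compound 4 (1.74 log units; beyond the scatter) shows that 2,5-dihydroxyphenyl on this saturated chain carbon also gives a large drop, as 2,4-dihydroxyphenyl did, so the drop is not tied to a single dihydroxy pattern. The step of a 4.2-fold lower number from compound 3 to compound 4 (0.62 log units; beyond the scatter) is modest but beyond the scatter, and it shows that 2,5-dihydroxyphenyl also gives a lower number than 4-hydroxyphenyl. The step of a 1.7-fold higher number from compound 2 to compound 4 (0.23 log units; within the scatter) leaves the two dihydroxyphenyl patterns unseparated.

Nothing available explains any of these steps. Still open, going by these compounds, is whether methoxy in place of hydroxy, an amine or a carboxylic acid on this aromatic ring, or a longer chain in place of the saturated chain carbon would keep numbers of this size.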